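Adding a Chloro Group to Compound 3

The source may hold more compounds than are shown below. What is called first, only, known or untested is meant among the compounds shown, and "the series" means these compounds.

Compound 1 `COc1ccc(COc2cc(O)c3c(=O)cc(C)oc3c2[C@H]2CCN(C)C[C@H]2O)cc1` gives 15%
Compound 2 `Cc1oc2c([C@H]3CCN(C)C[C@H]3O)c(O)cc(O)c2c(=O)c1C(O)c1ccc([N+](=O)[O-])cc1` gives 2%
Compound 3 `CN1CC[C@H](c2c(O)cc(O)c3c(=O)cc(/C=C/c4ccccc4)oc23)[C@H](O)C1` gives 87%

These three compounds were tested in a functional assay on MIA PaCa-2 cells (Homo sapiens) for inhibition, read by MTT assay, with a stated time of 48 h, tested at 10 uM; on this read-out lower numbers stand for less inhibition of growth and higher numbers for more inhibition of growth at the one concentration tested. Compound 3 stands highest of the three, and both compound 1 and compound 2 lie below it by margins well beyond the usual scatter. Among the compounds with values here, the three compounds differ from one another in more than one place, so no measured pair isolates a single change. Among them, only compound 3 carries a 2-phenylethenyl group.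

The next compound in the account is compound 4 `CN1CC[C@H](c2c(O)cc(O)c3c(=O)cc(/C=C/c4ccc(Cl)cc4)oc23)[C@H](O)C1`, which has not yet been measured. Its structure departs from that of compound 3 by one change, (chloro in place of hydrogen on an aromatic carbon), with chloro in place of hydrogen on an aromatic carbon, para to a large group. This turns 2-phenylethenyl into 2-(4-chlorophenyl)ethenyl. The data give no direct measure of such a change, so the expectation starts from compound 3 at 87%, which is already high on this scale. No step beyond the scatter is expected in either direction, and the estimated step is a number 2 percentage points lower from compound 3 to compound 4 (within the scatter). The expected value for compound 4 is 85%, with an estimated range from 65% to 98%.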

Compound 4, percent growth inhibition at one concentration: 88%
Beside the measured number, compound 4's estimate is 3 percentage points below it, within the range that was stated.
By their numbers in this assay, from the lowest: compound 2; then compound 1; then compounds 3 and 4 (each within the scatter of the next).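

In this assay, within the data shown here, compound 3 and compound 4 form the first pair that differs in one place, and the reading is a number 1 percentage points higher from compound 3 to compound 4 (within the scatter). Chloro in place of hydrogen on an aromatic carbon, para to a large group, therefore gives a number that cannot be told apart from the parent's on this read-out, so 2-phenylethenyl and 2-(4-chlorophenyl)ethenyl stand level here, something the earlier compounds, which differ in more than one place, could not show. Nothing available explains this outcome or links it to any property of the chloro group.

On these data alone, whether this position would take an amine, a carboxylic acid or a methoxy group equally well remains open, as does whether the two compounds would stay level at lower concentrations, given that both sit high on the scale at the one concentration tested. As far as these compounds go, it also remains open how much of the number for compound 3 belongs to the 2-phenylethenyl group itself. Neither compound 1 nor compound 2 differs from compound 3 in one place only.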